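The source may hold more compounds than are shown below. What is called first, only, known or untested is meant among the compounds shown, and "the series" means these compounds.

Compound 3, `COc1ccc(Oc2ccccc2-c2ccsc2S(=O)(=O)N2CCN(C(=O)Nc3ccc([N+](=O)[O-])cc3)CC2)cc1OC`, in an assay for binding affinity to Apoptosis regulator Bcl-2 (Homo sapiens), read by fluorescence polarization, with stated times of 30 min and 20 min, tested at 100 uM (on this read-out higher numbers stand for more inhibition at the one concentration tested (going by the name of the read-out) and lower numbers for less inhibition), gives 17%. Among the three compounds measured, its number is the second highest, with compound 1, `COc1ccc(Oc2ccccc2-c2ccsc2S(=O)(=O)N2CCN(C(=S)Nc3ccc([N+](=O)[O-])cc3)CC2)cc1OC`, giving 16%, and compound 2, `COc1ccc(Oc2ccccc2-c2ccsc2S(=O)(=O)N2CCN(C(=O)Nc3cccc([N+](=O)[O-])c3)CC2)cc1OC`, giving 18%. All three numbers sit close together: the step of a number 1 percentage points higher from compound 1 to compound 3 (within the scatter), the step of a number 1 percentage points lower from compound 2 to compound 3 (within the scatter) and the step of a number 2 percentage points higher from compound 1 to compound 2 (within the scatter) are each within the scatter.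

Compound 4, `COc1ccc(Oc2ccccc2-c2ccsc2S(=O)(=O)N2CCN(C(=S)Nc3ccc(Cl)cc3)CC2)cc1OC`, differs from compound 3 in one place: a group of 10 heavy atoms (7 carbon, 1 nitrogen, 1 sulfur, 1 chlorine; one six-membered aromatic ring of carbon only) in place of a group of 12 heavy atoms (7 carbon, 2 nitrogen, 3 oxygen; one six-membered aromatic ring of carbon only), on an amine nitrogen in a ring. For the measured compounds named here, two measured steps bear on this change. The step of a number 1 percentage points higher from compound 1 to compound 3 (within the scatter) covers the exchange of the thiocarbonyl and carbonyl with the 4-nitrophenyl kept, and the step of a number 1 percentage points lower from compound 2 to compound 3 (within the scatter) covers the exchange of one ring substituent pattern for another; both were within the scatter. Going by the values given here, no measured step covers the exchange of the nitro group for chlorine, so that part of the change is without a comparison. On these grounds one expects no step beyond the scatter, with an estimated change of no change at the digits printed from compound 3 to compound 4 (within the scatter) for compound 4. Compound 4 is therefore estimated at 17%, within a range from 5% to 29%.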

Compound 4, a percentage reported as inhibition, at one concentration (the size of the read-out at that concentration, not a potency): 18%
Compound 4: middle estimate off by 1 percentage points, on the low side, within the range that was stated.
By their numbers in this assay, from the lowest: compounds 1, 3, 2 and 4 (each within the scatter of the next).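

In this assay, for the compounds shown here, the exchange of nitro for chloro, which no earlier pair covered, gives a number 2 percentage points higher from compound 1 to compound 4 (within the scatter) with the thiocarbonyl kept, so this ring substituent can change without a step beyond the scatter. The larger changes on the amine nitrogen in the ring, which alter the carbonyl or thiocarbonyl together with the ring substituent, behave the same way: they give a number 1 percentage points higher from compound 3 to compound 4 (within the scatter) and no change at the digits printed from compound 2 to compound 4 (within the scatter) and so leave the read-out flat across these four compounds. No evidence is at hand that would account for this flatness.

On these data alone, whether any group at this place can move the number beyond the scatter remains open. An amine or a carboxylic acid in place of chloro, or a longer chain in place of the aromatic ring, could still test that.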